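Fluoro for Methoxy on the Sulfonyl Aryl Ring

The source may report more compounds than this note shows. Statements on the series, on what has been measured and on what is new or still open speak of the compounds shown alone.

Measured compounds:
compound 1, `CC1CCN(c2c(S(=O)(=O)c3cc(F)cc(F)c3)cnc3cc(F)ccc23)CC1`: 77%
compound 2, `COCC1CCN(c2c(S(=O)(=O)c3ccc(F)cc3)cnc3cc(F)ccc23)CC1`: 76.1%
compound 3, `COc1ccc(S(=O)(=O)c2cnc3cc(F)ccc3c2N2CCC(C)CC2)cc1`: 90%

All three were tested in an assay on isolated protein for displacement of a labelled ligand from metabotropic glutamate receptor 5 (Homo sapiens), with a stated time of 60 min, tested at 1 uM; on this read-out higher numbers stand for more inhibition at the one concentration tested (going by the name of the read-out) and lower numbers for less inhibition. Compound 3 stands highest of the three numbers; compound 1 is nearest, compound 2 furthest, and both gaps lie beyond the scatter. Among the compounds with values here, the only single-place step among the measured compounds is a number 13 percentage points higher from compound 1 to compound 3 (beyond the scatter), a modest rise in this assay when the methoxy-bearing ring replaced the difluoro-bearing one.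

Compound 4, `CC1CCN(c2c(S(=O)(=O)c3ccc(F)cc3)cnc3cc(F)ccc23)CC1`, differs from compound 3 by fluoro in place of methoxy on an aromatic carbon. Within the data shown here, no measured pair isolates this exact exchange, so the bearing is indirect. The step of a number 13 percentage points higher from compound 1 to compound 3 (beyond the scatter) shows that the methoxy-bearing ring outscored a fluorinated ring on the same core. The same 4-fluorophenyl as in compound 4, though with a different piperidine substituent, is carried by compound 2, which in this assay gives 76.1%, close to compound 1. Taken together, compound 4 is expected to fall back toward those two, with an estimated a number 13 percentage points lower from compound 3 to compound 4 (beyond the scatter). The estimate for compound 4 in this assay is 77%, with a range from 65% to 88%.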

Compound 4, a percentage reported as inhibition, at one concentration (the size of the read-out at that concentration, not a potency): 74.5%
For compound 4 the middle estimate is 2.5 percentage points above the measured one; measured number inside the range.
By their numbers in this assay, from the lowest: compounds 4, 2 and 1 (each within the scatter of the next); then compound 3.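

In this assay the direct exchange gives a number 15.5 percentage points lower from compound 3 to compound 4 (beyond the scatter), so the advantage of the 4-methoxyphenyl ring, earlier seen only against a 3,5-difluorophenyl ring, now also holds against 4-fluorophenyl at this place para to a large group on the shared core. The other two comparisons, a number 2.5 percentage points lower from compound 1 to compound 4 (within the scatter) and a number 1.6 percentage points lower from compound 2 to compound 4 (within the scatter), both lie within the scatter, so this assay separates neither the two fluorinated rings nor hydrogen from methoxy on the saturated chain carbon. Nothing available accounts for the gap between methoxy and fluoro.

The compounds shown leave open whether the higher number is particular to methoxy at this place or would extend to ethoxy or an amine there. They also leave open whether the 4-methoxyphenyl ring would keep its advantage alongside the methoxymethyl piperidine of compound 2.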